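A 1-methyl-1H-tetrazol-5-yl group on the sulfur of compound 3

The source may hold more compounds than are shown below. What is called first, only, known or untested is meant among the compounds shown, and "the series" means these compounds.

In a functional assay on HepG2 cells (Homo sapiens) for antiproliferative activity, read by MTT assay, with a stated time of 48 h (on this read-out lower numbers stand for stronger inhibition and higher numbers for weaker inhibition), compound 1 (`COc1ccc(CN(C(=O)Cn2cc(COc3ccccc3)nn2)c2cc(OC)c(OC)c(OC)c2)cc1`) gives 20500 nM as its value, compound 2 (`COc1ccc(CN(C(=O)Cn2cc(CSc3nc4ccccc4s3)nn2)c2cc(OC)c(OC)c(OC)c2)cc1`) gives 49200 nM and compound 3 (`COc1ccc(CN(C(=O)Cn2cc(CSC3=NCCS3)nn2)c2cc(OC)c(OC)c(OC)c2)cc1`) gives 25000 nM on the same read-out. Compound 3 is separated from the other two by a 1.2-fold higher number from compound 1 to compound 3 (0.09 log units; within the scatter) and by a 2.0-fold lower number from compound 2 to compound 3 (0.29 log units; within the scatter) and so stands within the scatter of both. Only a 2.4-fold higher number from compound 1 to compound 2 (0.38 log units; beyond the scatter) goes beyond the scatter, and it is modest. Compound 4 (`COc1ccc(CN(C(=O)Cn2cc(CSc3nnnn3C)nn2)c2cc(OC)c(OC)c(OC)c2)cc1`) departs from compound 3 by a group of 6 heavy atoms (2 carbon, 4 nitrogen; one five-membered aromatic ring with 4 hetero atoms) in place of a group of 5 heavy atoms (3 carbon, 1 nitrogen, 1 sulfur; one five-membered non-aromatic ring with 2 hetero atoms), on a sulfur and by nothing else. Going by the values given here, the entering 1-methyl-1H-tetrazol-5-yl group appears in no measured compound, so the evidence is indirect. Among the compounds with values here, the one exchange measured on that same sulfur is a 2.0-fold lower number from compound 2 to compound 3 (0.29 log units; within the scatter) and it stayed within the scatter, so no step beyond the scatter is expected in this assay for this change. The expected step is a 1.1-fold higher number from compound 3 to compound 4 (0.05 log units; within the scatter) and it is a small one. For compound 4 the estimate is 28000 nM with a range of 13000 nM to 60000 nM as its expected bounds.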

Compound 4, half-maximal inhibitory concentration: 28300 nM
Compound 4: the middle estimate sits 1.0-fold (0.00 log units) below what was measured, and the stated range covers the measured number.
By their numbers in this assay, from the lowest: compounds 1, 3, 4 and 2 (each within the scatter of the next, the first and the last beyond it).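

On the sulfur whose other neighbour is a saturated chain carbon, this assay now has a third group to compare: the 1-methyl-1H-tetrazol-5-yl group, a five-membered aromatic ring with 4 hetero atoms, gives a 1.1-fold higher number from compound 3 to compound 4 (0.05 log units; within the scatter) against the non-aromatic ring. Set against 1,3-benzothiazol-2-yl on that sulfur, it gives a 1.7-fold lower number from compound 2 to compound 4 (0.24 log units; within the scatter), so all three groups measured there lie within the scatter of one another, whether their ring is aromatic or not. The exchange of phenoxy for (1-methyl-1H-tetrazol-5-yl)sulfanyl gives a 1.4-fold higher number from compound 1 to compound 4 (0.14 log units; within the scatter), so compound 4 stays within the scatter of compound 1, which compound 2 does not.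

Nothing available explains why these groups read alike. Going by these compounds, whether an amine or a carboxylic acid on this sulfur, or a longer chain in place of the saturated chain carbon, would move the number beyond the scatter remains open.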